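The source may report more compounds than this note shows. Statements on the series, on what has been measured and on what is new or still open speak of the compounds shown alone.

compound 1 `COc1ccccc1/C=C/C(=O)NO`: 53500 nM
compound 2 `CN1CCN(C(=O)ONC(=O)/C=C/c2ccccc2OC(=O)c2ccccc2)CC1`: > 100000 nM

Both compounds were tested in a functional assay on A549 cells (Homo sapiens) for inhibition, read by ELISA, with a stated time of 24 h; a higher number here means a weaker inhibitor of growth, a lower number a stronger inhibitor of growth. For compound 2, the reading of > 100000 nM is a limit of the assay and not a number. Compound 3 `O=C(/C=C/c1ccccc1OC(=O)c1ccccc1)NOC(=O)c1ccccc1` has not yet been measured. It differs from compound 2 by phenyl in place of 4-methylpiperazin-1-yl on a carbonyl carbon, so that (4-methylpiperazin-1-yl)carbonyl becomes benzoyl. Within the data shown here, no measured pair shows what this change does, so the expectation is a loose one. It rests on compound 1, which gives a number in this assay at 53500 nM. A modest move towards stronger growth inhibition is expected, and it may not clear the scatter. The expected size of this move is an at least 1.4-fold lower number from compound 2 to compound 3 (0.15 log units; that floor lies within the scatter). For compound 3 the estimated value is 70000 nM, with an expected range of 20000 nM to 200000 nM.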

Compound 3, concentration for 50% growth inhibition: 8800 nM
For compound 3 the middle estimate is 8.0-fold (0.90 log units) above the measured one, outside the stated range (below it).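

In this assay, among these compounds, phenyl in place of 4-methylpiperazin-1-yl on a carbonyl carbon gives an at least 11-fold lower number from compound 2 to compound 3 (1.05 log units; beyond the scatter), the first reading of what this change does at this position. Compound 2 reads > 100000 nM, which is a limit of the assay and not a number. The step is therefore a floor, and its full size cannot be read, because one of its ends rests on that limit: the limit of > 100000 nM in this assay, at which 1 of the 3 values shown sits.

The compounds shown leave open whether the benzoyl group is special here or whether another group on this carbonyl carbon, such as cyclohexyl, methyl or piperidin-1-yl, would give a similar number. They also leave open how a phenyl ring carrying a methoxy group or an amine would compare with compound 3.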